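A few compounds are considered here, and "the series" means these few. Any claim that something is new, unique, unknown or untested is made for them only; others in the source may bear on it.

Measured in a functional assay on HCT-116 cells (Homo sapiens) for antiproliferative activity, read by MTT assay, with a stated time of 48 h (a higher number here means a weaker inhibitor, a lower number a stronger inhibitor), so far:
Compound 1 `COc1cc(/C=C/C(C)=O)ccc1OCc1cn(-c2ccccc2OC)nn1` reads 25700 nM in this assay
Compound 2 `COc1cc(/C=C/C(C)=O)ccc1OCc1cn(-c2ccc(NC(=O)c3ccccc3)cc2)nn1` reads > 100000 nM as a limit, not a number
Compound 3 `CCOC(=O)c1ccc(-n2cc(COc3ccc(/C=C/C(C)=O)cc3OC)nn2)cc1` reads 78900 nM in this assay

Compound 1 holds the lower of the two actual numbers, and compound 3 lies above it by more than the scatter.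

Compound 4 `COc1cc(/C=C/C(C)=O)ccc1OCc1cn(-c2ccccc2O)nn1` differs from compound 1 by hydrogen in place of methyl on an oxygen on an aromatic ring, which makes 2-methoxyphenyl into 2-hydroxyphenyl. Among the compounds with values here, the only measured step, an at least 1.2-fold lower number from compound 2 to compound 3 (0.10 log units; that floor lies within the scatter), puts ethoxycarbonyl in place of benzamido. That is a different change, and its floor lies within the scatter, so it offers no size to carry over. No step beyond the scatter is therefore expected in this assay, in either direction, and the expected step is a 1.0-fold lower number from compound 1 to compound 4 (0.01 log units; within the scatter) with wide uncertainty. Compound 4 is estimated at 25000 nM, with an expected range from 8000 nM to 75000 nM in this assay.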

Compound 4, half-maximal inhibitory concentration: 76400 nM
Beside the measured number, compound 4's estimate is 3.1-fold (0.49 log units) below it, outside the stated range (above it).
By their numbers in this assay, from the lowest: compound 1; then compounds 4 and 3 (each within the scatter of the next). At a limit, above all of these: compound 2.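

In this assay, the change from 2-methoxyphenyl to 2-hydroxyphenyl gives a 3.0-fold higher number from compound 1 to compound 4 (0.47 log units; beyond the scatter). This is the first step beyond the scatter among the compounds shown, so the methyl on this oxygen does register in the reading. No measurement shown accounts for this step. Open, from the compounds shown here alone, is whether the methyl itself counts or any other group in its place would serve equally. An ethoxy group or a longer chain on this oxygen, or an amine in place of the methoxy, would begin to separate these readings.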